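The source may report more compounds than this note shows. Statements on the series, on what has been measured and on what is new or still open speak of the compounds shown alone.

Among the compounds with values here, compound 2 `CC(C)c1onc(-c2c(Cl)cccc2Cl)c1COc1ccc(C(=O)N(Cc2ccccc2)c2ccc(C(=O)O)cc2)c(Cl)c1` gives 41% in a functional assay on HEK293 cells for agonist activity at Bile acid receptor (Homo sapiens), read by a luciferase reporter (on this read-out higher numbers stand for larger maximal responses and lower numbers for smaller maximal responses), the higher of the two numbers measured so far; compound 1 `CC(C)c1onc(-c2c(Cl)cccc2Cl)c1COc1ccc(C(=O)N(c2cccc(C(=O)O)c2)c2cccc3ccccc23)c(Cl)c1` gives 28% in this assay, a value that lies beyond the usual scatter below that of compound 2. Compound 3 `CC(C)c1onc(-c2c(Cl)cccc2Cl)c1COc1ccc(C(=O)N(Cc2ccccc2)c2cccc(C(=O)O)c2)c(Cl)c1` has the same atoms as compound 2 joined differently: 3-carboxyphenyl in place of 4-carboxyphenyl on an amide-type nitrogen. Within the data shown here, no measured pair isolates this change, so no step for it is known. The author expects a modest fall, with the step from a number 8 percentage points lower from compound 2 to compound 3 (within the scatter) likely within or just beyond the scatter. Compound 3 is therefore estimated at 33%, with a range from 15% to 55%.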

Compound 3, largest response reached (reported as efficacy), in percent of the reference or control that the assay uses: 31%
The estimate for compound 3 lay 2 percentage points above the measured number; the measured number falls inside the stated range.
By their numbers in this assay, from the lowest: compounds 1, 3 and 2 (each within the scatter of the next, the first and the last beyond it).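

In this assay the swap of 4-carboxyphenyl for 3-carboxyphenyl on the amide-type nitrogen gives a number 10 percentage points lower from compound 2 to compound 3 (within the scatter) and so does not separate the two placements. Benzyl in place of naphthalen-1-yl on that nitrogen, with 3-carboxyphenyl kept, gives a number 3 percentage points higher from compound 1 to compound 3 (within the scatter) and does not separate these two groups either. Nothing measured here bears on the reason for either step. Still open, going by these compounds, is whether a tetrazole in place of the carboxylic acid, or 2-phenylethyl in place of benzyl on the amide-type nitrogen, would shift the response beyond the scatter.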